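Propyl in place of hydrogen: compound 2 to compound 3

The source may report more compounds than this note shows. Statements on the series, on what has been measured and on what is new or still open speak of the compounds shown alone.

Values from a functional assay on HeLa cells (Homo sapiens) for antiproliferative activity, read by sulforhodamine B assay (on this read-out lower numbers stand for stronger inhibition of growth and higher numbers for weaker inhibition of growth), so far:
- compound 1 `O[C@H]1CO[C@H](COCc2ccccc2)[C@@H](OCc2ccccc2)[C@@H]1OCc1ccccc1` gives > 50000 nM (a limit)
- compound 2 `CC[C@@H]1O[C@H](COCc2ccccc2)[C@@H](OCc2ccccc2)[C@H](OCc2ccccc2)C1=O` gives > 50000 nM (a limit)

Compound 2 offers no number to work from: its reading of > 50000 nM is a limit of the assay. Within the data shown here, the series so far shows only the limit of > 50000 nM in this assay, at which 2 of the 2 values shown sit, and no measured step. Compound 3 `CCCCC[C@@H]1O[C@H](COCc2ccccc2)[C@@H](OCc2ccccc2)[C@H](OCc2ccccc2)C1=O` differs from compound 2 by propyl in place of hydrogen on a saturated chain carbon, two bonds along the chain from a saturated ring carbon. Among the measured compounds shown here, with no step to go by, no change beyond the usual scatter is expected in this assay and the reading may well stay at the limit. The estimated move an at least 1.1-fold lower number from compound 2 to compound 3 (0.04 log units; that floor lies within the scatter) is accordingly small. For compound 3 the expected value is 45000 nM with an estimated range from 12000 nM to 100000 nM on this read-out.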

Compound 3, concentration for 50% growth inhibition: > 50000 nM
Compound 3 ended at the assay's limit; the forecaster's own chance of this, stated with the estimate: 60%; middle value at least 1.1-fold (0.04 log units) away from the limit.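

Compound 2 and compound 3 both give limits, not numbers, in this assay, so no step between them can be read: the limit of > 50000 nM in this assay, at which 3 of the 3 values shown sit.

The compounds shown leave open whether any change to the shared core gives a measurable number in this assay.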